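Chlorophenyl amides: notes on growth inhibition

The compounds below may be only part of what the source reports. "The series", "measured", "known", "first", "only" and "open" are said of these compounds alone.

Compound 1 `CC(=O)SCCC(CCCCC(=O)O)SC(C)=O`: 8.03%
Compound 2 `O=C(CCCCC1CCSS1)NO`: 12.4%
Compound 3 `CC(=O)SCCC(CCCCC(=O)Nc1ccccc1Cl)SC(C)=O`: 6.93%

All three values come from a functional assay on KB cells (Homo sapiens) for inhibition, read by MTT assay, with a stated time of 24 h, tested at 100 ug/mL; a lower number here means less inhibition of growth, a higher number more inhibition of growth at the concentration tested. Compound 3, at 6.93%, lies within the scatter of both compound 1 and compound 2. Compound 4 `CC(=O)SCCC(CCCCC(=O)Nc1ccc(Cl)cc1)SC(C)=O` carries the next change, 4-chlorophenyl in place of 2-chlorophenyl on an amide-type nitrogen. Among the measured compounds shown here, the only measured step at this place is a number 1.1 percentage points lower from compound 1 to compound 3 (within the scatter), and it stays within the scatter. For the measured compounds named here, no measured step moves the chlorine around the ring. No shift beyond the scatter is therefore expected in this assay. The expected change is a number 1.1 percentage points higher from compound 3 to compound 4 (within the scatter). The estimated value for compound 4 is 8%, with an expected range of 3% to 16%.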

Compound 4, percent growth inhibition at one concentration: 72%
Beside the measured number, compound 4's estimate is 64 percentage points below it; the whole stated range lies below it.
By their numbers in this assay, from the lowest: compounds 3, 1 and 2 (each within the scatter of the next); then compound 4.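

In this assay, 4-chlorophenyl in place of 2-chlorophenyl on an amide-type nitrogen gives a number 65.1 percentage points higher from compound 3 to compound 4 (beyond the scatter), although the two compounds hold the same atoms. The chlorophenyl amide alone therefore does not settle the result: the 4-chlorophenyl amide gives a number 64 percentage points higher from compound 1 to compound 4 (beyond the scatter), while the 2-chlorophenyl change stayed within the scatter. No evidence at hand explains the step.

Whether the chlorine itself is required remains open, as the compounds shown include neither an unsubstituted phenyl amide nor a 4-fluorophenyl amide. As far as these compounds go, with one concentration per compound, the concentration response of compound 4 also remains open.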